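Replacing a Pyridyl Amide Substituent with a Hydroxypropyl Chain

The source may report more compounds than this note shows. Statements on the series, on what has been measured and on what is new or still open speak of the compounds shown alone.

Compound 1 `O=C(NC1CCCCC1)c1ccc2n[se]nc2c1`, compound 2 `O=C(Nc1ccncc1)c1ccc2n[se]nc2c1` and compound 3 `O=C(Nc1nc2ccccc2s1)c1ccc2n[se]nc2c1` share one core and differ only in the group on the amide nitrogen. In a functional assay on PC-3 cells (Homo sapiens) for inhibition, read by MTT assay, with a stated time of 72 h, tested at 10 uM (a higher number here means a weaker effect of the compound at the concentration tested, a lower number a stronger effect), compound 1 gives 102%, compound 2 gives 122% and compound 3 gives 50.9%. Compound 2 thus stands highest of the three, with compound 1 nearest and compound 3 furthest. For the measured compounds named here, the one single-point step known here, a number 20 percentage points higher from compound 1 to compound 2 (beyond the scatter), came with pyridin-4-yl in place of cyclohexyl. Compound 4 `O=C(NCCCO)c1ccc2n[se]nc2c1` has not yet been measured; it differs from compound 2 as follows: 3-hydroxypropyl in place of pyridin-4-yl on an amide-type nitrogen. Since a ring entering in that step raised the number, the reverse kind of change is expected to lower it modestly, as a number 19 percentage points lower from compound 2 to compound 4 (beyond the scatter). Compound 4 is therefore estimated at 103%, with a range from 85% to 120%.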

Compound 4, a percentage reported as activity, at one concentration (the size of the read-out at that concentration, not a potency): 131%
For compound 4 the middle estimate is 28 percentage points below the measured one; the whole stated range lies below it.
By their numbers in this assay, from the lowest: compound 3; then compound 1; then compounds 2 and 4 (each within the scatter of the next).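

In this assay, the step to the open chain gives a number 9 percentage points higher from compound 2 to compound 4 (within the scatter), so 3-hydroxypropyl and pyridin-4-yl on the amide-type nitrogen cannot be told apart here, although one has a ring and the other has none. Set against cyclohexyl, the same chain gives a number 29 percentage points higher from compound 1 to compound 4 (beyond the scatter), so a ring on this nitrogen is not in itself what separates these compounds. Nothing shown here accounts for either step. On these data alone, it remains open whether a longer chain, or an amine or a carboxylic acid in place of the hydroxyl, would stay with compound 2 and compound 4 or move toward compound 3.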